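This account rests on a few compounds, and the source may have more. Where it says the series, first, only, none or still open, it means among the compounds named here.

Measured compounds:
compound 1, `O=C1C(=O)N(CCCCn2cc(COc3cc(=O)oc4ccccc34)nn2)c2ccc([N+](=O)[O-])cc21`, gives 45% in a functional assay on COLO 205 cells (Homo sapiens) for inhibition, read by sulforhodamine B assay, with a stated time of 48 h, tested at 50 uM; a higher number here means more inhibition of growth at the concentration tested, a lower number less inhibition of growth;
compound 2, `COc1ccc2c(c1)C(=O)C(=O)N2CCCCn1cc(COc2cc(=O)oc3ccccc23)nn1`, gives 41%;
compound 3, `COc1ccc2c(c1)C(=O)C(=O)N2CCCCCn1cc(COc2cc(=O)oc3ccccc23)nn1`, gives 19%.

Compound 1 and compound 2 share a core and differ only by nitro in place of methoxy on an aromatic carbon; this gives a number 4 percentage points higher from compound 2 to compound 1 (within the scatter). Compound 3 differs from compound 2 in the core, and the difference between the two cores is not broken down here; compound 3 sits at the low end of the three numbers, beyond the scatter from both others. Compound 4, `O=C1C(=O)N(CCCCCn2cc(COc3cc(=O)oc4ccccc34)nn2)c2ccc([N+](=O)[O-])cc21`, has not been measured. It arises from compound 3 by nitro in place of methoxy on an aromatic carbon, the same change as from compound 2 to compound 1. Because that earlier step was a number 4 percentage points higher from compound 2 to compound 1 (within the scatter), a small step is expected here too, estimated as a number 4 percentage points higher from compound 3 to compound 4 (within the scatter). For compound 4 the expected value is 23%, likely between 10% and 38%.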

Compound 4, percent growth inhibition at one concentration: 23%
Compound 4: middle estimate and measured number agree at the digits printed; the measured number falls inside the stated range.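

In this assay, nitro in place of methoxy on an aromatic carbon gives a number 4 percentage points higher from compound 3 to compound 4 (within the scatter). Set beside the earlier step, the change carries from one core to the other with no difference that can be told apart: the same change on two cores in this assay, a number 4 percentage points higher (within the scatter) from compound 2 to compound 1 and a number 4 percentage points higher (within the scatter) from compound 3 to compound 4, 0 percentage points apart, within the scatter of two such steps This shows that on these two cores the exchange stays within the scatter, but it does not show that the same would hold on any other core, and two small steps give no reason for the result.

The compounds shown leave open whether another group on that aromatic carbon, such as an amine or a carboxylic acid, would move the number beyond the scatter. They also leave open how either group behaves with a longer chain.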